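Chloro in place of methyl across two unmeasured-core pairs

The source may hold more compounds than are shown below. What is called first, only, known or untested is meant among the compounds shown, and "the series" means these compounds.

Compound 1 `Cc1ccc(NC(=O)COc2nc3ccccc3nc2C)cc1` was run in a functional assay on MCF7 cells (Homo sapiens) for inhibition, read by MTT assay, with a stated time of 24 h; on this read-out higher numbers stand for weaker inhibition and lower numbers for stronger inhibition. In this assay compound 1 gives > 100000 nM, which is a limit of the assay and not a number. Compound 2 `Cc1nc2ccccc2nc1OCC(=O)Nc1ccc(Cl)cc1` carries the change (chloro in place of methyl on an aromatic carbon). In this assay compound 2 gives > 100000 nM, likewise a limit. The step that the two limits leave unreadable from compound 1 to compound 2 accordingly cannot be sized. Compound 3 `Cc1ccc(C(=O)Nc2ccc(Cn3c(=O)c(C)nc4ccccc43)cc2)cc1` rests on a different core; how the core of compound 3 differs from the core of compound 1 is not broken down here. In this assay compound 3 gives > 100000 nM, again a limit. Among the measured compounds shown here, compound 4 `Cc1nc2ccccc2n(Cc2ccc(NC(=O)c3ccc(Cl)cc3)cc2)c1=O` is not yet measured and differs from compound 3 by chloro in place of methyl on an aromatic carbon, which is the same change as the one between compound 1 and compound 2, made at a place described in the same words.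

For the measured compounds named here, since the limit of > 100000 nM in this assay, at which 3 of the 3 values shown sit, holds for every measured compound, no sized step is available in this assay to carry over. The step expected in this assay is therefore a step that the limit leaves unreadable from compound 3 to compound 4, which means no readable movement. Compound 4 is estimated at 150000 nM in this assay, most likely reported again only as a limit.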

Compound 4, half-maximal inhibitory concentration: 47600 nM
Beside the measured number, compound 4's estimate is 3.2-fold (0.50 log units) above it; measured number below the stated range.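

On the core of compound 3, chloro in place of methyl on an aromatic carbon gives, in this assay, an at least 2.1-fold lower number from compound 3 to compound 4 (0.32 log units; beyond the scatter), so the change is readable on this core. On the core of compound 1 the same step cannot be read, and compound 2 gives > 100000 nM, a limit of the assay and not a number. The result therefore neither confirms nor refutes carrying the change from one core to another, because a sized step exists on only one of the two cores, and even that step has a lower bound rather than a full size: the limit of > 100000 nM in this assay, at which 3 of the 4 values shown sit.

Compound 4, at 47600 nM, is the only compound shown with a value that is a number, so it remains open whether any change on the core of compound 1 would bring a value into the readable range. Also open is whether the shift is specific to chloro, since no amine, carboxylic acid or longer chain stands in its place among the compounds shown.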